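The source may report more compounds than this note shows. Statements on the series, on what has been measured and on what is new or still open speak of the compounds shown alone.

In a functional assay on K562 cells (Homo sapiens), read by MTT assay, with a stated time of 72 h (a higher number here means a weaker inhibitor, a lower number a stronger inhibitor), compound 3 `CN(C)c1ncnc2c1c(-c1ccoc1)cn2[C@@H]1O[C@H](CO)[C@@H](O)[C@H]1O` gives 14900 nM, the higher of the two actual numbers in the series. Compound 1 `C#Cc1cn([C@@H]2O[C@H](CO)[C@@H](O)[C@H]2O)c2ncnc(SC)c12` gives 70 nM, far lower and beyond the scatter. Compound 2 `CNc1ncnc2c1c(-c1ccoc1)cn2[C@@H]1O[C@H](CO)[C@@H](O)[C@H]1O` gives > 20000 nM, which is a limit of the assay and not a number.

Compound 4 `C#Cc1cn([C@@H]2O[C@H](CO)[C@@H](O)[C@H]2O)c2ncnc(N(C)C)c12` is reached through (ethynyl in place of furan-3-yl on an aromatic carbon), that is, ethynyl in place of furan-3-yl on an aromatic carbon. Going by the values given here, the only measured step, an at least 1.3-fold lower number from compound 2 to compound 3 (0.12 log units; that floor lies within the scatter), is methyl in place of hydrogen on a nitrogen on an aromatic ring. Its floor lies within the scatter and it leaves this carbon untouched, so it gives no size for the change.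

Among the compounds with values here, the sole guide is compound 1, the only measured compound with ethynyl, at 70 nM. It also differs from compound 3 in a second place, so only part of that gap is expected to carry over in this assay, towards a lower number. The expected change is a 9.9-fold lower number from compound 3 to compound 4 (1.00 log units; beyond the scatter). For compound 4 the estimate is 1500 nM, with an expected range of 150 nM to 14000 nM.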

Compound 4, half-maximal inhibitory concentration: 260 nM
Compound 4: middle estimate off by 5.8-fold (0.76 log units), on the high side, within the range that was stated.
By their numbers in this assay, from the lowest: compound 1; then compound 4; then compound 3. At a limit, above all of these: compound 2.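

In this assay, the aromatic carbon two ring bonds from the ring nitrogen proves highly sensitive to its substituent: with dimethylamino held constant, ethynyl in place of furan-3-yl gives a 57-fold lower number from compound 3 to compound 4 (1.76 log units; beyond the scatter). The earlier step left this carbon untouched, so this is the only clean size for the change in the series. The ring atom bearing dimethylamino also matters with ethynyl held constant, as dimethylamino in place of methylsulfanyl gives a 3.7-fold higher number from compound 1 to compound 4 (0.57 log units; beyond the scatter).

As far as these compounds go, it remains open whether a nitrile, an aminomethyl group or a longer chain ending in a triple bond at the same carbon would keep numbers as low as those with ethynyl. Compound 2 gives a value that is a limit of the assay and not a number: the limit of > 20000 nM in this assay, at which 1 of the 4 values shown sits.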